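The compounds below may be only part of what the source reports. "The series", "measured", "known", "first", "only" and "open" are said of these compounds alone.

Measured in an ADME assay on NHDF cells (Homo sapiens) for cytotoxicity, read by MTT assay, with a stated time of 72 h; a higher number here means a weaker inhibitor, a lower number a stronger inhibitor:
- compound 1 `COc1cccc(/C=C2\CCC/C(=C\c3ccc(OC)c(OC)c3)C2=O)c1`: 11600 nM
- compound 2 `COc1ccc(/C=C2\CCC/C(=C\c3ccc(Cl)cc3Cl)C2=O)cc1OC`: > 50000 nM (a limit of the assay, not a number)

For the measured compounds named here, compound 1 holds the only true number so far, so there is no series to rank it against. Compound 2 sits at the limit, > 50000 nM.

The next compound, compound 3 `COc1ccc(/C=C2\CCC/C(=C\c3ccc(OC)c(OC)c3)C2=O)cc1OC`, is compound 1 with one small change: methoxy in place of hydrogen on an aromatic carbon. In words, a methoxy takes the place of a hydrogen on an aromatic carbon, ortho to a methoxy group and para to a large group.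

Going by the values given here, only one measured step bears on this: an at least 4.3-fold higher number from compound 1 to compound 2 (0.63 log units; beyond the scatter). That step swaps the whole 3-methoxyphenyl group for 2,4-dichlorophenyl, and this is the group that receives the new methoxy in compound 3. It shows that changes here can move the number, but it is a far larger edit than adding one methoxy. A small move towards a higher number in this assay is therefore expected, possibly none beyond the scatter.

The expected change is a 1.3-fold higher number from compound 1 to compound 3 (0.11 log units; within the scatter). For compound 3 the estimated value is 15000 nM, with an expected range from 5000 nM to 45000 nM.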

Compound 3, half-maximal inhibitory concentration: 9700 nM
Compound 3: middle estimate off by 1.5-fold (0.19 log units), on the high side; measured number inside the range.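

In this assay, adding a methoxy on an aromatic carbon, ortho to a methoxy group and para to a large group, gives a 1.2-fold lower number from compound 1 to compound 3 (0.08 log units; within the scatter), so this single change leaves the number within the usual scatter and this carbon can carry a methoxy with no readable change. The earlier step, an at least 4.3-fold higher number from compound 1 to compound 2 (0.63 log units; beyond the scatter), rests on a limit of the assay and replaces the whole 3-methoxyphenyl group with 2,4-dichlorophenyl, so the new result shows that a move of that size does not appear with this much smaller edit on the same group. Nothing measured here gives a reason for this result, and a step within the scatter asks for none.

Going by these compounds, only methoxy and hydrogen have been compared at this carbon, so it remains open whether a chlorine, an amine, a carboxylic acid or a longer chain such as butoxy would move the number beyond the scatter. For the compounds shown here, it is also open whether the same methoxy would behave in the same way on a compound with different groups elsewhere on the shared core, since this single pair is the only reading of this change.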